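The compounds below may be only part of what the source reports. "The series", "measured", "known", "first", "only" and "open" are said of these compounds alone.

Compound 1 `NCCNc1cc(N2CCN(S(=O)(=O)c3ccccc3)CC2)nc2ccccc12` in an ADME assay on HEp-2 cells (Homo sapiens) for cytotoxicity, read by CCK-8 assay, with a stated time of 6 days (on this read-out lower numbers stand for higher toxicity in this test and higher numbers for lower toxicity in this test), gives 20500 nM. Compound 2 `CS(=O)(=O)N1CCN(c2cc(NCCN)c3ccccc3n2)CC1` returns only a limit in this assay, > 100000 nM. The step of an at least 4.8-fold higher number from compound 1 to compound 2 (0.68 log units; beyond the scatter) accordingly rests on the limit of > 100000 nM in this assay, at which 1 of the 2 values shown sits, and is known only as a lower bound. Compound 3 `CC(C)C(=O)N1CCN(c2cc(NCCN)c3ccccc3n2)CC1` differs from compound 2 by isopropylcarbonyl in place of methylsulfonyl on an amine nitrogen in a ring. Among the compounds with values here, the one measured step, phenyl to methyl on the sulfonyl sulfur, bears only loosely on exchanging the whole methylsulfonyl for isopropylcarbonyl, so no step beyond the scatter is firmly expected. For compound 3 a value of 70000 nM is estimated, within 25000 nM to 200000 nM. This estimate means an at least 1.4-fold lower number from compound 2 to compound 3 (0.15 log units; that floor lies within the scatter).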

Compound 3, half-maximal cytotoxic concentration: > 100000 nM
Compound 3: only a limit was reported; the forecaster's own chance of this, stated with the estimate: 45%; middle value at least 1.4-fold (0.15 log units) from the limit.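

Isopropylcarbonyl in place of phenylsulfonyl gives an at least 4.8-fold higher number from compound 1 to compound 3 (0.68 log units; beyond the scatter), so a sulfonyl link on this ring nitrogen is not required for the higher number in this assay. Compound 3 is reported only as a limit, > 100000 nM. The step from compound 2 cannot be read, because both compounds sit at the same limit: the limit of > 100000 nM in this assay, at which 2 of the 3 values shown sit.

As far as these compounds go, whether a benzoyl group on this nitrogen, pairing the phenyl ring with a carbonyl link, would return the number towards that of compound 1 remains open.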